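The source may hold more compounds than are shown below. What is called first, only, known or untested is meant among the compounds shown, and "the series" means these compounds.

Compound 1 `O=C(NOCc1ccccc1Cl)c1cn(-c2ccccc2)nc1-c1ccccc1` gives 7410 nM in a functional assay on MCF7 cells (Homo sapiens) for antiproliferative activity, read by MTT assay, with a stated time of 48 h, in the presence of a further agent that is not named here; on this read-out higher numbers stand for weaker inhibition of growth and lower numbers for stronger inhibition of growth; compound 2 `COc1ccc(-c2nn(-c3ccccc3)cc2C(=O)NOCc2ccccc2Cl)cc1` gives 3730 nM; compound 3 `O=C(NOCc1ccccc1F)c1cn(-c2ccccc2)nc1-c1ccc(Cl)cc1` gives 15100 nM.

Compound 3 holds the highest number of the three, above compound 1 and further above compound 2. The step to compound 4 `O=C(NOCc1ccccc1Cl)c1cn(-c2ccccc2)nc1-c1ccc(Cl)cc1` is chloro in place of fluoro on an aromatic carbon. Among the compounds with values here, no measured step covers this change: the only step recorded, a 2.0-fold lower number from compound 1 to compound 2 (0.30 log units; within the scatter), concerns a different group and lies within the scatter. Compound 1, which carries the chloro group but lacks the chloro on the other ring, differs from compound 3 in two places, so its value merely sits lower. The expected change is therefore none beyond the scatter, a 1.4-fold lower number from compound 3 to compound 4 (0.14 log units; within the scatter). Compound 4 is estimated at 11000 nM, between 4000 nM and 30000 nM.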

Compound 4, concentration for 50% growth inhibition: 16100 nM
Estimate against measurement, compound 4: 1.5-fold (0.17 log units) below; measured number inside the range.
By their numbers in this assay, from the lowest: compounds 2 and 1 (each within the scatter of the next); then compounds 3 and 4 (each within the scatter of the next).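

In this assay the change from 2-fluorobenzyl to 2-chlorobenzyl leaves the number unchanged within the scatter (a 1.1-fold higher number from compound 3 to compound 4 (0.03 log units; within the scatter)), so at this place either halogen gives the same read-out when the other ring carries chloro. On that other ring, the chloro group gives a modest rise beyond the scatter, both in place of hydrogen (a 2.2-fold higher number from compound 1 to compound 4 (0.34 log units; beyond the scatter)) and in place of methoxy (a 4.3-fold higher number from compound 2 to compound 4 (0.64 log units; beyond the scatter)). No measurement offered here explains these steps.

As far as these compounds go, whether an amine or a carboxylic acid in place of the halogen on the benzyl ring would hold the number remains open. So does the effect of a longer chain in place of the benzyl group.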